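Swapping a Benzyl Ether Arm for a Carbamate Chain

The source may hold more compounds than are shown below. What is called first, only, known or untested is meant among the compounds shown, and "the series" means these compounds.

This study tracks a small set of compounds in an assay on MCF7 cells for inhibition of Serine-protein kinase ATM (Homo sapiens), read by immunofluorescence, with a stated time of 1 h; a lower number here means a stronger inhibitor, a higher number a weaker inhibitor. Compound 1 `COc1cc2ncnc(-n3cnc(-c4ccccn4)n3)c2cc1OC` gives 5300 nM in this assay. For the measured compounds named here, compound 2 `COc1cc2ncnc(-n3nc(-c4ccccn4)nc3N)c2cc1OCc1ccccc1` carries a benzyl ether on its shared core and gives 8600 nM in this assay, the highest of the two numbers so far; the gap to compound 1 lies within the scatter of repeated measurements, so the two compounds cannot be told apart on these figures.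

Compound 3 `COc1cc2ncnc(-n3nc(-c4ccccn4)nc3N)c2cc1OCCCNC(=O)OCC(C)(C)C` has not yet been measured. It differs from compound 2 in a single place: 2-((neopentyloxycarbonyl)amino)ethyl in place of phenyl on a saturated chain carbon bound to an oxygen on an aromatic ring. Going by the values given here, no measured pair in the set shows what such a change does, so there is no step to lean on, and only the two weak starting values remain as a guide. The expectation for compound 3 is therefore a step from compound 2 that stays within the scatter, a 1.1-fold lower number from compound 2 to compound 3 (0.03 log units; within the scatter), in either direction. The estimate for compound 3 in this assay is 8000 nM, with a range from 2500 nM to 25000 nM.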

Compound 3, half-maximal inhibitory concentration: 1900 nM
For compound 3 the middle estimate is 4.2-fold (0.62 log units) above the measured one; measured number outside the range, below it.
By their numbers in this assay, from the lowest: compound 3; then compounds 1 and 2 (each within the scatter of the next).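

For the compounds shown here, the saturated chain carbon bound to an oxygen on an aromatic ring proves to be a place where the attached group can shift the number in this assay: placing 2-((neopentyloxycarbonyl)amino)ethyl there in place of phenyl gives a 4.5-fold lower number from compound 2 to compound 3 (0.66 log units; beyond the scatter) and is the first change in this set to clear the scatter. The swap changes several things at once, since the aromatic ring of the benzyl ether leaves and a ring-free chain enters, bringing a carbonyl, a hydrogen-bond donor and hydrogen-bond acceptors that phenyl lacks. No measurement in this set accounts for the lower number or assigns it to any one of these features.

Going by these compounds, what remains open is which part of the new arm matters: a plain propyl chain, or the same chain ending in a primary amine or a carboxylic acid, would help separate the chain from the carbamate. A methyl carbamate in place of the neopentyl carbamate would likewise test whether the bulky end of the chain contributes to the step or is merely carried along.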